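The source may hold more compounds than are shown below. What is called first, only, known or untested is meant among the compounds shown, and "the series" means these compounds.

Measured compounds in this series:

- compound 1, `COc1ccc(C(=O)/C=C/c2cn(-c3ccccc3)nc2-c2cccnc2)c(OC)c1OC`: in a functional assay on HCT-116 cells (Homo sapiens) for inhibition, read by sulforhodamine B assay, with a stated time of 72 h (on this read-out lower numbers stand for stronger inhibition and higher numbers for weaker inhibition), compound 1 gives 1100 nM
- compound 2, `COc1ccc(C(=O)/C=C/c2cn(-c3ccccc3)nc2-c2cccnc2)cc1OC`: in this assay compound 2 gives 4300 nM

Among the compounds with values here, compound 2 stands at the highest of the two numbers; its only neighbour is compound 1, and the step from compound 1 to compound 2 is a 3.9-fold higher number from compound 1 to compound 2 (0.59 log units; beyond the scatter), a single change of hydrogen in place of methoxy on an aromatic carbon.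

Compound 3, `COc1ccc(C(=O)/C=C/c2cn(-c3ccccc3)nc2-c2ccncc2)cc1OC`, is the next candidate. It differs from compound 2 in one place: pyridin-4-yl in place of pyridin-3-yl on an aromatic carbon. The two have the same atoms, joined differently, so only the attachment of the pyridinyl group moves.

Within the data shown here, no measured step bears on this change. Among the measured compounds shown here, the one step recorded concerns the methoxy group and says nothing about moving from pyridin-3-yl to pyridin-4-yl. For the measured compounds named here, with no comparable precedent, the expectation for compound 3 is a step of no change at the digits printed from compound 2 to compound 3 (within the scatter), that is, none beyond the scatter in either direction. Compound 3 is therefore estimated at 4300 nM, with a range from 1400 nM to 13000 nM.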

Compound 3, half-maximal inhibitory concentration: 1200 nM
Compound 3: middle estimate off by 3.6-fold (0.55 log units), on the high side; the measured number lies below the stated range.
By their numbers in this assay, from the lowest: compounds 1 and 3 (each within the scatter of the next); then compound 2.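

In this assay, the attachment of the pyridinyl group alone moves the read-out: a 3.6-fold lower number from compound 2 to compound 3 (0.55 log units; beyond the scatter), although the groups that leave and enter have the same heavy atoms, hydrogen-bond donor and acceptor counts, and charge. Within the data shown here, this position, on the aromatic carbon next to the ring nitrogen of the five-membered ring, is therefore a second place where a single change goes beyond the scatter, alongside the methoxy change in a 3.9-fold higher number from compound 1 to compound 2 (0.59 log units; beyond the scatter); the earlier compounds showed nothing about this position, since both carry pyridin-3-yl. No measured evidence is available here to account for the difference between the two pyridinyl attachments.

The methoxy step is shown only with pyridin-3-yl, so whether it carries over in size or direction to a pyridin-4-yl compound remains open. Also open, from the compounds shown here alone, is how the read-out responds at this carbon to pyridin-2-yl, or to a pyridin-4-yl ring bearing an amine or a methyl group, so two attachment points give no trend for this position.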